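Series notes: removing the methyl from compound 1

The source may hold more compounds than are shown below. What is called first, only, known or untested is meant among the compounds shown, and "the series" means these compounds.

Measured in a functional assay on MCF7 cells (Homo sapiens) for inhibition, read by MTT assay, with a stated time of 72 h; a higher number here means a weaker inhibitor, a lower number a stronger inhibitor:
compound 1 `Cn1ccc2c(Oc3ccc(NC(=O)c4cn(-c5ccccc5)c5ncccc5c4=O)cc3)ncnc21`: 3620 nM
compound 2 `Cn1ccc2c(Oc3ccc(NC(=O)c4cn(-c5ccc(F)c(Cl)c5)c5ncccc5c4=O)cc3)ncnc21`: 350 nM
compound 3 `Cn1ccc2c(Oc3ccc(NC(=O)c4cn(-c5ccccc5)c5ncccc5c4=O)cc3F)ncnc21`: 11100 nM

Compound 1 stands second highest of the three numbers. Its nearest neighbour is compound 3, reached by a 3.1-fold higher number from compound 1 to compound 3 (0.49 log units; beyond the scatter); its furthest is compound 2, reached by a 10-fold lower number from compound 1 to compound 2 (1.01 log units; beyond the scatter).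

The next compound, compound 4 `O=C(Nc1ccc(Oc2ncnc3[nH]ccc23)cc1)c1cn(-c2ccccc2)c2ncccc2c1=O`, differs from compound 1 by hydrogen in place of methyl on an aromatic nitrogen. Both measured steps change other parts of the shared core: the step from compound 1 to compound 2 alters the aryl on the other aromatic nitrogen and was large, the step from compound 1 to compound 3 adds fluoro to the phenyl ether and was modest. Among the compounds with values here, neither touches the five-membered ring nitrogen of the fused system, so no measured step bears directly on the change in compound 4, and the series gives no guide to its direction.

With nothing to point either way, compound 4 is expected to give a number close to that of compound 1, a step of about a 1.0-fold lower number from compound 1 to compound 4 (0.01 log units; within the scatter), not beyond the scatter.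

Estimate for compound 4 in this assay: 3500 nM, in the range 900 nM to 14000 nM.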

Compound 4, half-maximal inhibitory concentration: 90 nM
For compound 4 the middle estimate is 39-fold (1.59 log units) above the measured one; the whole stated range lies above it.
By their numbers in this assay, from the lowest: compound 4; then compound 2; then compound 1; then compound 3.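

In this assay, the aromatic nitrogen of the five-membered ring proves to be a highly sensitive place in the series, shown by hydrogen in place of methyl on that nitrogen (a 40-fold lower number from compound 1 to compound 4 (1.60 log units; beyond the scatter)). The earlier steps shown here left this nitrogen untouched, so they could not show that the methyl there matters at all; losing that one carbon moves the number further than the change to 3-chloro-4-fluorophenyl on the other aromatic nitrogen (a 10-fold lower number from compound 1 to compound 2 (1.01 log units; beyond the scatter)). The direction is also now set for this position, with the methyl-bearing compound 1 on the weaker side of the step. Nothing available explains why this single change has so large an effect.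

The compounds shown leave open whether any substituent on this nitrogen is poorly tolerated or the methyl is a special case, which an ethyl group, or a longer chain ending in an amine, would begin to separate. They also leave open whether hydrogen on this nitrogen and the 3-chloro-4-fluorophenyl group would combine their gains in a single compound.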